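Rearranging a hydroxyphenyl group on a shared pyridine-free core

The compounds below may be only part of what the source reports. "The series", "measured", "known", "first", "only" and "open" are said of these compounds alone.

Of the compounds shown here, two have been measured in a functional assay on T47D cells (Homo sapiens) for inhibition; on this read-out higher numbers stand for weaker inhibition and lower numbers for stronger inhibition. Compound 1 `Oc1cccc(-c2cc(-c3ccc(F)cc3)cc(-c3cccc(O)c3)n2)c1` gives 6870 nM. Compound 2 `Oc1cccc(-c2cc(-c3ccc(OC(F)(F)F)cc3)cc(-c3ccccc3O)n2)c1` gives 7710 nM, the higher of the two numbers, though the gap to compound 1 lies within the scatter, so no order between them can be claimed.

Compound 3 `Oc1cccc(-c2cc(-c3ccc(OC(F)(F)F)cc3)cc(-c3cccc(O)c3)n2)c1` has not yet been measured. It differs from compound 2 in one place: 3-hydroxyphenyl in place of 2-hydroxyphenyl on an aromatic carbon. The two have the same atoms, joined differently, so only the point of attachment of the hydroxyl on that ring changes. Among the compounds with values here, no measured pair shows the effect of this rearrangement, so nothing can be said about its size from the data; compound 1, which already carries the 3-hydroxyphenyl group, sits within the scatter of compound 2, which is the only hint that this part of the core is tolerant to either arrangement.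

Compound 3 is therefore expected to stay close to compound 2, with the step from compound 2 to compound 3 of a 1.2-fold lower number from compound 2 to compound 3 (0.07 log units; within the scatter) not reaching beyond the scatter. In this assay compound 3 is estimated at 6500 nM, within a range of 2500 nM to 16000 nM.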

Compound 3, half-maximal inhibitory concentration: 9820 nM
The estimate for compound 3 lay 1.5-fold (0.18 log units) below the measured number, within the range that was stated.
By their numbers in this assay, from the lowest: compounds 1, 2 and 3 (each within the scatter of the next).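

In this assay, 3-hydroxyphenyl in place of 2-hydroxyphenyl next to the ring nitrogen gives a 1.3-fold higher number from compound 2 to compound 3 (0.11 log units; within the scatter), so this first direct reading of the rearrangement shows no change that can be told from the scatter. With 3-hydroxyphenyl kept on both sides, trifluoromethoxy in place of fluoro on an aromatic carbon gives a 1.4-fold higher number from compound 1 to compound 3 (0.16 log units; within the scatter), so this exchange on the shared core cannot be resolved either, and neither single step separates its two compounds in this assay. No other evidence bears on these results.

On these data alone, what remains open is whether this position responds to anything more than a shift of the hydroxyl, since a ring carrying an amine, a carboxylic acid or a methoxy group in its place, or a 4-hydroxyphenyl group, could show whether the hydroxyl matters at all. As far as these compounds go, it is also open whether a group other than fluoro or trifluoromethoxy, such as a morpholine or a longer alkoxy chain, would produce a step that rises beyond the scatter on the shared core.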